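Removing a methyl from an inactive spiro pyrazolone pair

The compounds below may be only part of what the source reports. "The series", "measured", "known", "first", "only" and "open" are said of these compounds alone.

Compound 1 `CC1=NN(c2ccc(Br)cc2)C(=O)C12C=CC(=O)C=C2c1cccc(C)c1` was tested in a functional assay on HCT-116 cells (Homo sapiens) for antiproliferative activity, read by CCK-8 assay, with a stated time of 72 h; on this read-out higher numbers stand for weaker inhibition and lower numbers for stronger inhibition. In this assay compound 1 gives > 100000 nM, which is a limit of the assay rather than a number. Compound 2 `CC1=NN(c2ccccc2)C(=O)C12C=CC(=O)C=C2c1cccc(C)c1` carries hydrogen in place of bromo on an aromatic carbon, and in this assay compound 2 gives > 100000 nM, again a limit. The step that the two limits leave unreadable from compound 1 to compound 2 therefore cannot be read. Within the data shown here, the only evidence on the measured values is the limit of > 100000 nM in this assay, at which 2 of the 2 values shown sit, so compound 1 stands at the edge of what this assay can see, with nothing to rank it against.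

Compound 3 `CC1=NN(c2ccc(Br)cc2)C(=O)C12C=CC(=O)C=C2c1ccccc1` is the compound still to be measured. It differs from compound 1 by hydrogen in place of methyl on an aromatic carbon. Among the measured compounds shown here, no measured step concerns this change; the one step recorded, between compound 1 and compound 2, is itself unreadable. The expectation for compound 3 is therefore that it also sits at the limit, with a step that the limit leaves unreadable from compound 1 to compound 3 not readable beyond scatter. Compound 3 is estimated at 150000 nM, within 50000 nM to 500000 nM.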

Compound 3, half-maximal inhibitory concentration: > 100000 nM
Compound 3: no number, only a limit; the forecaster's own chance of this, stated with the estimate: 85%; the middle value does not contradict the limit.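

In this assay compound 3 gives > 100000 nM, which is a limit and not a number. Among these compounds, no step among compound 1, compound 2 and compound 3 can be read, since all three rest on the same limit: the limit of > 100000 nM in this assay, at which 3 of the 3 values shown sit. From the compounds shown here alone, it remains open whether swapping the bromo or the methyl for hydrogen changes activity at all.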